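A few compounds are considered here, and "the series" means these few. Any claim that something is new, unique, unknown or untested is made for them only; others in the source may bear on it.

Compound 1 `C#Cc1cccc(Nc2ncnc3cc(OCCOC(=O)C(C)c4ccc(CC(C)C)cc4)c(OCCOC)cc23)c1`: 2200 nM
Compound 2 `C#Cc1cccc(Nc2ncnc3cc(OCCOC(=O)C(C)c4ccc5cc(OC)ccc5c4)c(OCCOC)cc23)c1`: 3200 nM
Compound 3 `C#Cc1cccc(Nc2ncnc3cc(OCCOC)c(OCCOC(=O)C(C)c4ccc(CC(C)C)cc4)cc23)c1`: a limit, > 10000 nM

In a functional assay on A-431 cells (Homo sapiens) for antiproliferative activity, read by CCK-8 assay, with a stated time of 72 h (a lower number here means a stronger inhibitor, a higher number a weaker inhibitor), compound 1 gives 2200 nM and compound 2 gives 3200 nM. Compound 2 differs from compound 1 by 6-methoxynaphthalen-2-yl in place of 4-isobutylphenyl on a saturated chain carbon bound to a carbonyl carbon and a saturated chain carbon, and this step was a 1.5-fold higher number from compound 1 to compound 2 (0.16 log units; within the scatter). Compound 3 has the same atoms as compound 1, joined differently; the difference between the two cores is not broken down here. For compound 3 the assay reports only a limit, > 10000 nM, which is the limit of > 10000 nM in this assay, at which 1 of the 3 values shown sits.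

Compound 4 `C#Cc1cccc(Nc2ncnc3cc(OCCOC)c(OCCOC(=O)C(C)c4ccc5cc(OC)ccc5c4)cc23)c1` differs from compound 3 by 6-methoxynaphthalen-2-yl in place of 4-isobutylphenyl on a saturated chain carbon bound to a carbonyl carbon and a saturated chain carbon, the same change that was made from compound 1 to compound 2. That earlier step, a 1.5-fold higher number from compound 1 to compound 2 (0.16 log units; within the scatter), stayed within the scatter, so no large shift is expected here either. Because compound 3 already gives only the limit > 10000 nM, compound 4 is expected to remain at or beyond that limit. The expected step is estimated as a step that the limit leaves unreadable from compound 3 to compound 4. Compound 4 is therefore estimated at 15000 nM, with a range from 7000 nM to 40000 nM, most likely reported again only as a limit.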

Compound 4, half-maximal inhibitory concentration: 5000 nM
For compound 4 the middle estimate is 3.0-fold (0.48 log units) above the measured one, and the stated range ends above it.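

In this assay the change from 4-isobutylphenyl to 6-methoxynaphthalen-2-yl gave an at least 2.0-fold lower number from compound 3 to compound 4 (0.30 log units; that floor lies within the scatter) and so did not carry over from one core to the other with the same size or direction: the same change on two cores in this assay, a 1.5-fold higher number (0.16 log units; within the scatter) from compound 1 to compound 2 and an at least 2.0-fold lower number (0.30 log units; that floor lies within the scatter) from compound 3 to compound 4, at least 2.9-fold (0.46 log units) apart, beyond the scatter of two such steps. Compound 3 gives only a limit of > 10000 nM and not a number, so this step is a floor and its full size cannot be read. Within the data shown here, with only two pairs, the result shows that the outcome of this change differed on these two cores, but it does not show why, nor how the change would behave on any other core.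

The compounds shown leave open whether the same difference between the two cores would appear with an amide in place of the ester, or with a longer chain carrying the ester. They also leave open whether a free carboxylic acid in place of the ester would give a similar result in this assay on either core.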